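Swapping Hydroxymethyl for Tert-Butyl in a Seizure Model

The source may report more compounds than this note shows. Statements on the series, on what has been measured and on what is new or still open speak of the compounds shown alone.

Of the compounds shown here, three sharing one core have been tested in a functional assay on the whole organism with Mus musculus as the target, in the maximal electroshock model, with a stated time of 30 min; on this read-out lower numbers stand for an effect already at smaller amounts and higher numbers for an effect only at larger amounts of compound. Compound 1 `Cc1cc(Oc2ccccc2)c[n+]([O-])c1` gives 100 mg/kg. Compound 2 `N#Cc1cc[n+]([O-])cc1Oc1ccccc1` gives 300 mg/kg in this assay, and compound 3 `[O-][n+]1ccc(CO)c(Oc2ccccc2)c1` gives 300 mg/kg. Compound 3 thus stands level with compound 2, and the two together hold the highest numbers of the three, while compound 1 sits a clear step lower, beyond the usual scatter. Among the compounds with values here, the only single-point step among the measured compounds is no change at the digits printed from compound 2 to compound 3 (within the scatter), where a hydroxymethyl replaced a cyano group on an aromatic carbon.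

Compound 4 `CC(C)(C)c1cc[n+]([O-])cc1Oc1ccccc1` differs from compound 3 by one change: tert-butyl in place of hydroxymethyl on an aromatic carbon. Within the data shown here, no measured step swaps a hydroxymethyl for a tert-butyl, so the change itself is uncharted. What is known is that exchanging one group for another on this aromatic carbon, cyano for hydroxymethyl, moved nothing in no change at the digits printed from compound 2 to compound 3 (within the scatter). On that basis the step of no change at the digits printed from compound 3 to compound 4 (within the scatter) is expected to lie within the scatter. The estimate for compound 4 in this assay is therefore 300 mg/kg, with a range from 100 mg/kg to 1000 mg/kg that is kept wide since a tert-butyl has not been tested in this series.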

Compound 4, minimum effective dose: 30 mg/kg
Estimate against measurement, compound 4: 10-fold (1.00 log units) above; measured number outside the range, below it.
By their numbers in this assay, from the lowest: compound 4; then compound 1; then compounds 2 and 3 (each within the scatter of the next).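

In this assay, the aromatic carbon opposite the ring nitrogen proves sensitive to what it carries: tert-butyl in place of hydroxymethyl gives a 10-fold lower number from compound 3 to compound 4 (1.00 log units; beyond the scatter), and tert-butyl in place of cyano gives a 10-fold lower number from compound 2 to compound 4 (1.00 log units; beyond the scatter) on the same carbon. The earlier exchange of cyano for hydroxymethyl left the number unchanged at the digits printed, so it could have suggested that groups here make little difference, whereas these two steps show that a change at this carbon can bring the effect down to clearly smaller amounts of compound. Tert-butyl has more heavy atoms than hydroxymethyl and no hydrogen-bond donor or acceptor, but nothing available here links either difference to the shift, so these counts remain a description of the change.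

From the compounds shown here alone, it remains open whether the lower number belongs to tert-butyl alone or would also appear with a methyl, an isopropyl or a cyclopropyl on this carbon. How an amine or a carboxylic acid at the same place would read in this assay is also unanswered.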